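A few compounds are considered here, and "the series" means these few. Any claim that something is new, unique, unknown or untested is made for them only; others in the source may bear on it.

Measured in a physicochemical assay for lipophilicity; a higher number here means a more lipophilic compound, a lower number a more polar compound:
- Compound 1 `CCNC(=O)Nc1ccc(-c2nc(CS(C)(=O)=O)cc([C@]34CCOC[C@H]3C4)n2)cc1`: 3.6
- Compound 2 `CCNC(=O)Nc1ccc(-c2nc(C(C)(C)S(C)(=O)=O)cc([C@@]34CCOC[C@@H]3C4)n2)cc1`: 4.7

Of these two compounds, compound 2 stands higher at 4.7, while compound 1 reads 3.6, a gap beyond the scatter of repeated measurements. Going by the values given here, with only two numbers, this says little about any wider trend.

Compound 3 `CCNC(=O)Nc1ccc(-c2nc(C(C)(C)S(C)(=O)=O)cc([C@]34CCOC[C@H]3C4)n2)cc1` has not yet been measured in this assay. Its difference from compound 2 is the two compounds have the same atoms and bonds and differ only in configuration as drawn: 2 of 2 stereo elements differ (all stereocentres are inverted: mirror images); a stereocentre at a saturated ring carbon is drawn S in compound 2 and R in compound 3; a stereocentre at a saturated ring carbon is drawn R in compound 2 and S in compound 3. The two compounds therefore have the same atoms and bonds and are mirror images, with all stereocentres inverted.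

Among the compounds with values here, no pair of measured compounds shows what such an inversion does to this assay. The expectation must come from general reasoning: a partition measurement does not normally tell mirror images apart, so no step beyond the scatter is expected, in either direction. The expected size of the change is no change at the digits printed from compound 2 to compound 3 (within the scatter). The best guide is therefore compound 2 at 4.7. The estimate for compound 3 is 4.7, with an expected range from 4.4 to 5.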

Compound 3, partition coefficient: 4.7
Compound 3: middle estimate and measured number agree at the digits printed; the range from low to high includes it.
By their numbers in this assay, from the lowest: compound 1; then compounds 2 and 3 (each within the scatter of the next).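

In this assay, inverting both stereocentres gives no change at the digits printed from compound 2 to compound 3 (within the scatter), and one point accounts for this absence of a step, since a partition measurement does not normally tell mirror images apart: the fact that compounds 2 and 3 differ only in the configuration as drawn

Compound 3 also has the same configuration as drawn as compound 1, which gives a comparison the earlier numbers could not: compound 1 and compound 2 differ both in the group on the aromatic carbon and in configuration, whereas compound 1 and compound 3 differ in one place only. With 1-methyl-1-(methylsulfonyl)ethyl in place of (methylsulfonyl)methyl on an aromatic carbon, the result is a number 1.10 log units higher from compound 1 to compound 3 (beyond the scatter), a large step that can now be tied to this swap alone rather than to a mix of two changes.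

The compounds shown leave open how a 1-(methylsulfonyl)ethyl group, which would sit structurally between these two, would read at this position, and whether an amine or a carboxylic acid there would move the number in the opposite direction. They also leave open whether compound 2 and compound 3 would stay alike in a biological assay, where mirror images can behave differently.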